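The compounds below may be only part of what the source reports. "The series", "measured", "known", "first", "only" and "open" are said of these compounds alone.

Measured compounds:
compound 1 `O=C(Nc1ccc(C(F)(F)F)cc1)c1ccc2ccccc2n1`, > 90000 nM
compound 2 `O=C(Nc1cc(C(F)(F)F)cc(C(F)(F)F)c1)C1CCc2ccccc2N1C(=O)c1ccccc1Cl`, 2080 nM
compound 3 `CC(=O)N1c2ccccc2CCC1C(=O)Nc1cc(C(F)(F)F)cc(C(F)(F)F)c1`, > 70000 nM

In a functional assay on NCI-H23 cells (Homo sapiens) for cytotoxicity, read by sulforhodamine B assay, with a stated time of 72 h (a lower number here means a stronger inhibitor of growth, a higher number a weaker inhibitor of growth), compound 3 sits at a limit, (the limit of > 70000 nM in this assay, at which 1 of the 3 values shown sits), with no number of its own. Compound 1 likewise sits at a limit, (the limit of > 90000 nM in this assay, at which 1 of the 3 values shown sits). Compound 2 is the only one of the three with a measured number in this assay. The change to compound 4 `O=C(Nc1cc(C(F)(F)F)cc(C(F)(F)F)c1)C1CCc2ccccc2N1C(=O)c1ccc(Cl)cc1` is 4-chlorophenyl in place of methyl on a carbonyl carbon. Within the data shown here, the one measured step that bears on it runs the other way: an at least 33-fold higher number from compound 2 to compound 3 (1.52 log units; beyond the scatter). Compound 2 carries a 2-chlorophenyl on the same carbonyl carbon, and compound 4 a 4-chlorophenyl. A large fall in the number is therefore expected for compound 4, an at least 28-fold lower number from compound 3 to compound 4 (1.44 log units; beyond the scatter). Compound 4 is estimated at 2500 nM, within 800 nM to 12000 nM.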

Compound 4, concentration for 50% growth inhibition: 889 nM
Compound 4: middle estimate off by 2.8-fold (0.45 log units), on the high side; the measured number falls inside the stated range.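

In this assay, among these compounds, the 2-chlorophenyl is no longer the only aryl group with a measured number on this carbonyl carbon, and moving the chlorine on the phenyl ring registers: a 2.3-fold lower number from compound 2 to compound 4 (0.37 log units; beyond the scatter). With 4-chlorophenyl in place of methyl the shift is large, an at least 78-fold lower number from compound 3 to compound 4 (1.89 log units; beyond the scatter), so the large difference from the acetyl compound holds for both chlorophenyl groups. That step rests on a limit and not a number for compound 3: the limit of > 70000 nM in this assay, at which 1 of the 4 values shown sits.

As far as these compounds go, what an unsubstituted phenyl, a 3-chlorophenyl or a cyclohexyl on this carbonyl carbon would give remains open. The compounds shown also give no reason for the gap between the 2-chlorophenyl and 4-chlorophenyl groups.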